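The compounds below may be only part of what the source reports. "The series", "measured", "known", "first", "only" and "open" are said of these compounds alone.

Of the compounds shown here, three have so far been measured in an assay on Sf21 cells for inhibition of cytochrome c oxidase subunit 2 (Homo sapiens), read by spectrophotometry, with a stated time of 5 min; a higher number here means a weaker inhibitor, a lower number a stronger inhibitor. Compound 1 `COc1ccc(C(=O)CC2CC(=O)N(c3ccc(S(N)(=O)=O)cc3)C2=O)cc1` gives 2100 nM. Compound 3 `CC1CCC(=O)C(C2CC(=O)N(Cc3ccccc3)C2=O)C1` gives 21900 nM, and compound 2 `O=C1CCCCCC1C1CC(=O)N(c2ccccc2)C1=O` gives 39500 nM. Compound 1 therefore stands at the lowest number of the three, with compound 3 the nearest to it and compound 2 the furthest away, and both of those gaps lie beyond the usual scatter of this kind of measurement.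

Compound 4 `NS(=O)(=O)c1ccc(N2C(=O)CC(CC(=O)c3ccccc3)C2=O)cc1` has not yet been measured. It differs from compound 1 in one place: hydrogen in place of methoxy on an aromatic carbon, which amounts to turning the 4-methoxyphenyl into a phenyl, the methoxy having sat para to a large group. Among the measured compounds shown here, no two measured compounds here differ by a single change, so there is no precedent for this step. Because compound 1 sits at 2100 nM and the change removes only the methoxy, compound 4 is expected to remain close to it, with at most a modest drift toward a weaker value. The step expected is a 1.7-fold higher number from compound 1 to compound 4 (0.22 log units; within the scatter), a small weakening that may not clear the scatter. Compound 4 is thus estimated at 3500 nM, within a range from 1200 nM to 10000 nM.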

Compound 4, half-maximal inhibitory concentration: 4230 nM
Beside the measured number, compound 4's estimate is 1.2-fold (0.08 log units) below it, and the stated range covers the measured number.
By their numbers in this assay, from the lowest: compounds 1 and 4 (each within the scatter of the next); then compounds 3 and 2 (each within the scatter of the next).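

In this assay, swapping the 4-methoxyphenyl of compound 1 for the phenyl of compound 4 gives a 2.0-fold higher number from compound 1 to compound 4 (0.30 log units; within the scatter) and so leaves the two compounds indistinguishable. Among the compounds shown here, this is the first single-change comparison, and it shows that, on this core, inhibition at the level of compound 1 does not depend on having a methoxy on the aromatic carbon para to a large group, although this rests on one pair alone. Nothing measured here offers an explanation for this result.

Still open, on these data alone, is how this position would respond to a different group, such as a hydroxyl, an amine, a chlorine atom or a longer ethoxy chain. Also open, as far as these compounds go, is whether hydrogen in place of methoxy would read the same way on any other core.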